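Nitroimidazole acetyl sulfonamides: swapping the aryl substituent

The compounds below may be only part of what the source reports. "The series", "measured", "known", "first", "only" and "open" are said of these compounds alone.

Measured so far in a functional assay on B16-F10 cells (Mus musculus) for antiproliferative activity, read by MTT assay, with a stated time of 48 h; on this read-out higher numbers stand for weaker inhibition and lower numbers for stronger inhibition:
compound 1 `Cc1ncc([N+](=O)[O-])n1CC(=O)NS(=O)(=O)c1ccc(F)cc1` gives 0.35 ug/mL
compound 2 `O=C(Cc1ccc(F)cc1)NS(=O)(=O)c1ccc(Cl)cc1` gives 6.36 ug/mL
compound 3 `O=C(Cc1ccc(F)cc1)NS(=O)(=O)c1ccccc1` gives 9.07 ug/mL

Compound 1 has the lowest number of the three; compound 2 and compound 3, which carry a different acyl part, both sit well beyond the scatter above it. Compound 4 `Cc1ccc(S(=O)(=O)NC(=O)Cn2c([N+](=O)[O-])cnc2C)cc1` keeps the core of compound 1 and differs only in methyl in place of fluoro on an aromatic carbon. Within the data shown here, the one measured step that touches the same ring, a 1.4-fold higher number from compound 2 to compound 3 (0.15 log units; within the scatter), is within the scatter, so a change of the substituent on the sulfonyl aryl ring has so far moved this assay little. Accordingly no step beyond the scatter is expected, a 1.4-fold higher number from compound 1 to compound 4 (0.15 log units; within the scatter). Compound 4 is estimated at 0.5 ug/mL, within 0.15 ug/mL to 1.6 ug/mL.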

Compound 4, half-maximal inhibitory concentration: 3.55 ug/mL
For compound 4 the middle estimate is 7.1-fold (0.85 log units) below the measured one; the measured number lies above the stated range.
By their numbers in this assay, from the lowest: compound 1; then compounds 4, 2 and 3 (each within the scatter of the next, the first and the last beyond it).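

In this assay the change from 4-fluorophenyl to 4-methylphenyl on the core of compound 1 gives a 10-fold higher number from compound 1 to compound 4 (1.01 log units; beyond the scatter) on a swap of a single heavy atom. The substituent on the sulfonyl aryl ring is therefore not a silent place on this core, which the step of a 1.4-fold higher number from compound 2 to compound 3 (0.15 log units; within the scatter) on a different acyl part and with a different swap did not reveal. Nothing on hand accounts for the size of this step.

Open, from the compounds shown here alone, is how hydrogen, chloro, methoxy or an amine in the same place would read on the core of compound 1. Also open, going by these compounds, is whether the swap of fluoro for methyl carries the same weight on the acyl part of compound 2.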